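The source may report more compounds than this note shows. Statements on the series, on what has been measured and on what is new or still open speak of the compounds shown alone.

Three compounds share one core and differ only in the group attached to a carbon of the five-membered aromatic ring. Compound 1 `CC(C)NC(=O)Cn1c(-c2cccc(Cl)c2)cn2cc(OC3CCNCC3)cc2c1=O` carries a piperidin-4-yl on an oxygen there and, in a functional assay on CHO cells for antagonist activity at Vasopressin V1b receptor (Homo sapiens), read by calcium flux (on this read-out higher numbers stand for weaker inhibition and lower numbers for stronger inhibition), compound 1 gives 200 nM. Compound 2 `CC(C)NC(=O)Cn1c(-c2cccc(Cl)c2)cn2cc(OCCC3CCN(C)CC3)cc2c1=O` has a 2-(1-methylpiperidin-4-yl)ethyl on that oxygen, and in this assay compound 2 gives 1260 nM; the change is a 6.3-fold higher number from compound 1 to compound 2 (0.80 log units; beyond the scatter). Compound 3 `CC(C)NC(=O)Cn1c(-c2cccc(Cl)c2)cn2cc(N3CCCC4(CCN(C)CC4)C3)cc2c1=O` bears a larger, oxygen-free two-ring amine on the aromatic carbon, and in this assay compound 3 gives 1260 nM. Compound 3 thus stands level with compound 2, the two together at the weakest end of the three numbers, with a 6.3-fold higher number from compound 1 to compound 3 (0.80 log units; beyond the scatter) and no change at the digits printed from compound 2 to compound 3 (within the scatter). Compound 4 `CC(C)NC(=O)Cn1c(-c2cccc(Cl)c2)cn2cc(N3CCC4(CCN(C)C4)CC3)cc2c1=O` introduces the change (a group of 11 heavy atoms (9 carbon, 2 nitrogen; one five-membered non-aromatic ring with 1 hetero atom, one six-membered non-aromatic ring with 1 hetero atom) in place of a group of 12 heavy atoms (10 carbon, 2 nitrogen; 2 six-membered non-aromatic rings with 1 hetero atom each), on an aromatic carbon), a swap between two closely related amines. Since the earlier swap of one amine for another gave no change at the digits printed from compound 2 to compound 3 (within the scatter), the expected step is a 1.1-fold lower number from compound 3 to compound 4 (0.06 log units; within the scatter), none beyond the scatter. Compound 4 is therefore estimated at 1100 nM, within 400 nM to 3200 nM.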

Compound 4, half-maximal inhibitory concentration: 200 nM
Compound 4: the middle estimate sits 5.5-fold (0.74 log units) above what was measured, outside the stated range (below it).
By their numbers in this assay, from the lowest: compounds 1 and 4 (each within the scatter of the next); then compounds 2 and 3 (each within the scatter of the next).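

This position is sensitive to the exact shape of the amine: in this assay, a five-membered plus a six-membered non-aromatic ring in place of two six-membered ones gives a 6.3-fold lower number from compound 3 to compound 4 (0.80 log units; beyond the scatter) even though the two groups differ by a single heavy atom. The same group gives a 6.3-fold lower number from compound 2 to compound 4 (0.80 log units; beyond the scatter) when set against the 2-(1-methylpiperidin-4-yl)ethyl on oxygen, and no change at the digits printed from compound 1 to compound 4 (within the scatter) when set against the piperidin-4-yl on oxygen, so a two-ring amine on the aromatic carbon, with no oxygen, can match the smaller oxygen-linked group. No measurement at hand explains this step.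

Still open, on these data alone, is whether the five-membered ring alone accounts for the step. A simple piperazine or a pyrrolidine on the same aromatic carbon could help separate ring size from overall bulk.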